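A Bicyclic Amide in Place of the Morpholine

The source may hold more compounds than are shown below. What is called first, only, known or untested is meant among the compounds shown, and "the series" means these compounds.

Three compounds share one core and differ only in the amide. In an assay on cells for inhibition of Palmitoleoyl-protein carboxylesterase NOTUM variant C330S (Homo sapiens), read by fluorescence, with a stated time of 40 min (a higher number here means a weaker inhibitor, a lower number a stronger inhibitor), compound 1 `CNC(=O)C1CCN(c2ccc(Cl)c(C(F)(F)F)c2)C1` gives 1300 nM, and compound 2 `CN(C)C(=O)C1CCN(c2ccc(Cl)c(C(F)(F)F)c2)C1` gives 1200 nM; the step of a 1.1-fold lower number from compound 1 to compound 2 (0.03 log units; within the scatter) lies within the scatter. Compound 3 `O=C(C1CCN(c2ccc(Cl)c(C(F)(F)F)c2)C1)N1CCOCC1` gives 9700 nM, the highest of the three numbers, and the steps of a 7.5-fold higher number from compound 1 to compound 3 (0.87 log units; beyond the scatter) and an 8.1-fold higher number from compound 2 to compound 3 (0.91 log units; beyond the scatter) are both beyond the scatter. Compound 4 `O=C(C1CCN(c2ccc(Cl)c(C(F)(F)F)c2)C1)N1CC2COCC2C1` has not yet been measured in this assay. It differs from compound 3 in that (a group of 8 heavy atoms (6 carbon, 1 nitrogen, 1 oxygen; 2 five-membered non-aromatic rings with 1 hetero atom each) in place of a group of 6 heavy atoms (4 carbon, 1 nitrogen, 1 oxygen; one six-membered non-aromatic ring with 2 hetero atoms), on a carbonyl carbon). Within the data shown here, the steps that bear on this change are a 7.5-fold higher number from compound 1 to compound 3 (0.87 log units; beyond the scatter) and an 8.1-fold higher number from compound 2 to compound 3 (0.91 log units; beyond the scatter), both running toward higher numbers as a cyclic amide replaced a small one, but no measured step tests a further enlargement of the cyclic amide. For compound 4 the expected step is a 1.2-fold higher number from compound 3 to compound 4 (0.09 log units; within the scatter), because an 8.1-fold higher number from compound 2 to compound 3 (0.91 log units; beyond the scatter) already placed compound 3 at the weak end and a still larger amide is not expected to reverse that. Compound 4 is estimated at 12000 nM, with a range from 4000 nM to 36000 nM.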

Compound 4, half-maximal inhibitory concentration: 3100 nM
Estimate against measurement, compound 4: 3.9-fold (0.59 log units) above, and the stated range ends above it.
By their numbers in this assay, from the lowest: compounds 2 and 1 (each within the scatter of the next); then compound 4; then compound 3.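

In this assay the larger bicyclic group on the carbonyl carbon does not extend the loss seen with morpholin-4-yl but partly reverses it, with a 3.1-fold lower number from compound 3 to compound 4 (0.50 log units; beyond the scatter), so heavy-atom count alone does not order these amides, and compound 3 is the one that goes against such an order. The recovery is incomplete: a 2.6-fold higher number from compound 2 to compound 4 (0.41 log units; beyond the scatter) and a 2.4-fold higher number from compound 1 to compound 4 (0.38 log units; beyond the scatter) both lie beyond the scatter, leaving compound 4 weaker than either small amide. Nothing measured here accounts for the difference between the two cyclic amides.

Open is where a pyrrolidine or piperidine amide, which carries no ring oxygen, would fall among these compounds. Also open, as far as these compounds go, is whether a bicyclic amide with a carbon in place of the ring oxygen of compound 4 would come closer to compound 1.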